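The compounds below may be only part of what the source reports. "The series", "measured", "known", "first", "only" and "open" are said of these compounds alone.

Compound 1 `O=C(/C=C/c1ccc([N+](=O)[O-])cc1)c1ccc[nH]1`: 26000 nM
Compound 2 `O=C(/C=C/c1ccccc1Br)c1ccc[nH]1`: 44000 nM

In a functional assay on HeLa cells (Homo sapiens) for inhibition, read by MTT assay, with a stated time of 48 h (a lower number here means a stronger inhibitor, a higher number a weaker inhibitor), compound 1 gives 26000 nM, the lowest of the two numbers measured, and compound 2 gives 44000 nM; the two values lie within the scatter of each other, so no order can be read from them. Compound 3 `O=C(/C=C/c1ccc(Br)cc1)c1ccc[nH]1` has not yet been measured. It differs from compound 1 by bromo in place of nitro on an aromatic carbon. Going by the values given here, no step between measured compounds covers this change, so the step from compound 1 to compound 3 in this assay is expected to stay within the scatter, a 1.3-fold higher number from compound 1 to compound 3 (0.13 log units; within the scatter). Compound 3 is estimated at 35000 nM, with a likely range from 15000 nM to 80000 nM.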

Compound 3, half-maximal inhibitory concentration: > 100000 nM
Compound 3 was reported as a limit; the forecaster's own chance of this, stated with the estimate: 10%; middle value at least 2.8-fold (0.45 log units) from the limit.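

Replacing nitro with bromo on this aromatic carbon, para to a group of 9 heavy atoms, gives an at least 3.8-fold higher number from compound 1 to compound 3 (0.58 log units; beyond the scatter) in this assay. Going by these compounds alone, this is the first single change that can be read, and it shows that the number at this position depends on the group it carries. On these data alone, for compound 3 the reading is a limit, so the full size of the step stays unknown: the limit of > 100000 nM in this assay, at which 1 of the 3 values shown sits.

The compounds shown leave open how an amine, a methoxy group or a carboxylic acid at this position would compare with nitro.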